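This account rests on a few compounds, and the source may have more. Where it says the series, first, only, none or still open, it means among the compounds named here.

Compound 1 `COc1ccc2c(O[C@H]3C[C@H]4C(=O)N(C)CCCC/C=C/[C@@H]5C[C@@]5(C(=O)NS(=O)(=O)C5(C)CC5)NC(=O)N4C3)cc(-c3nc(C(F)(F)F)cs3)nc2c1C`: 75000 nM
Compound 2 `COc1ccc2c(O[C@H]3C[C@H]4C(=O)N(C)CCCC/C=C/[C@@H]5C[C@@]5(C(=O)NS(=O)(=O)C5(C)CC5)NC(=O)N4C3)cc(-c3cc(C(C)C)on3)nc2c1Cl`: 75000 nM

In an ADME assay on Huh-7 cells (Homo sapiens) for cytotoxicity, read by colorimetric assay (a lower number here means that less compound is tolerated, a higher number that more compound is tolerated), compound 1 gives 75000 nM. Compound 2 gives 75000 nM in this assay, level with compound 1 at the digits shown, the two values lying within the usual scatter. Compound 3 `COc1ccc2c(O[C@H]3C[C@H]4C(=O)N(C)CCCC/C=C/[C@@H]5C[C@@]5(C(=O)NS(=O)(=O)C5(C)CC5)NC(=O)N4C3)cc(-n3cc(C(F)(F)F)cn3)nc2c1Cl` has not yet been measured; it differs from compound 2 in one place: 4-(trifluoromethyl)-1H-pyrazol-1-yl in place of 5-isopropyl-1,2-oxazol-3-yl on an aromatic carbon. Going by the values given here, no step between measured compounds is known, and the two measured values coincide, so no change beyond the scatter is expected. Compound 3 is estimated to give 75000 nM in this assay, between 40000 nM and 110000 nM. The expected step is therefore no change at the digits printed from compound 2 to compound 3 (within the scatter), essentially none.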

Compound 3, half-maximal cytotoxic concentration: 21900 nM
For compound 3 the middle estimate is 3.4-fold (0.53 log units) above the measured one; measured number below the stated range.
By their numbers in this assay, from the lowest: compound 3; then compounds 1 and 2 (each within the scatter of the next).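

In this assay, 4-(trifluoromethyl)-1H-pyrazol-1-yl in place of 5-isopropyl-1,2-oxazol-3-yl gives a 3.4-fold lower number from compound 2 to compound 3 (0.53 log units; beyond the scatter). The group on this aromatic carbon, next to the ring nitrogen, can therefore move the number beyond the scatter, even though both groups are five-membered aromatic rings with matching hydrogen-bond counts. Nothing available accounts for the change. As far as these compounds go, since ring and substituent change together, it remains open which of them carries the step. A 4-methyl-1H-pyrazol-1-yl group at this place would help separate the two.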